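Swapping tert-butyl for a silicon group on a urea

The compounds below may be only part of what the source reports. "The series", "measured", "known", "first", "only" and "open" are said of these compounds alone.

Compound 1 `CC(C)(C)c1ccccc1Oc1ncccc1NC(=O)Nc1ccc(C2(CO)CC2)cc1`: 176 nM
Compound 2 `CN(C)CC(C)(C)COc1ccc(NC(=O)Nc2cccnc2Oc2ccccc2C(C)(C)C)cc1`: 137 nM

In an assay on isolated protein for binding affinity to P2Y purinoceptor 1 (Homo sapiens) (a lower number here means a stronger inhibitor, a higher number a weaker inhibitor), compound 2 gives 137 nM, and compound 1 sits within the scatter of it, as the step of a 1.3-fold lower number from compound 1 to compound 2 (0.11 log units; within the scatter) shows. Compound 3 `CN(C)CC(C)(C)COc1ccc(NC(=O)Nc2cccnc2Oc2ccccc2[Si](C)(C)C)cc1` differs from compound 2 only by a group of 4 heavy atoms (3 carbon, 1 silicon; no ring) in place of a group of 4 heavy atoms (4 carbon; no ring), on an aromatic carbon, ortho to a large group. For the measured compounds named here, no measured step touches this position; the one step known concerns a different part of the molecule. With nothing to push the number either way, compound 3 is expected to stay close to compound 2, a step of a 1.0-fold higher number from compound 2 to compound 3 (0.01 log units; within the scatter), giving an estimate of 140 nM with a range from 55 nM to 360 nM.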

Compound 3, inhibition constant in the P2Y purinoceptor 1 assay: 163 nM
Compound 3: middle estimate off by 1.2-fold (0.07 log units), on the low side, within the range that was stated.
By their numbers in the P2Y purinoceptor 1 assay, from the lowest: compounds 2, 3 and 1 (each within the scatter of the next).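

In the P2Y purinoceptor 1 assay, exchanging tert-butyl for the group with one silicon and three carbon atoms gives a 1.2-fold higher number from compound 2 to compound 3 (0.08 log units; within the scatter) so this position accepts silicon with no readable change in binding. Lipophilicity does shift, as a physicochemical assay for lipophilicity, read by HPLC (on this read-out lower numbers stand for lower lipophilicity and higher numbers for higher lipophilicity), shows: the measured partition coefficient of compound 2, 5.1, and of compound 3, 4.7, a number 0.40 log units lower (beyond the scatter). In the physicochemical assay compound 2 gives 5.1 and compound 3 gives 4.7.

For the compounds shown here, the exchange has been seen only on the chain carried by compound 2, so its effect on the side chain of compound 1 remains open. Also open, going by these compounds, is how a smaller group such as methyl, or a trifluoromethyl, would fare on this aromatic carbon.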